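Swapping the thioester of compound 3 for a cyclopentyl ester

This account rests on a few compounds, and the source may have more. Where it says the series, first, only, none or still open, it means among the compounds named here.

Measured so far:
- compound 1, `CC1=C(C(=O)C2CC2)C(c2ccsc2)NC(=O)N1`: 1%
- compound 2, `CCN(CC)C(=O)C1=C(C)NC(=O)NC1c1ccsc1`: 35%
- compound 3, `CC1=C(C(=O)SC(C)C)C(c2ccsc2)NC(=O)N1`: 1%

All three share one core and differ only in the group on a carbonyl carbon. In an assay on membranes from HeLa cells for displacement of a labelled ligand from adenosine receptor A3 (Homo sapiens), read by scintillation counting, with a stated time of 180 min, tested at 1 uM (a lower number here means less inhibition, a higher number more inhibition at the concentration tested (going by the name of the read-out)), compound 3 gives 1%, level with compound 1 and together with it the lowest of the three numbers; only compound 2 stands apart, with a step of a number 34 percentage points lower from compound 2 to compound 3 (beyond the scatter).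

Compound 4, `CC1=C(C(=O)OC2CCCC2)C(c2ccsc2)NC(=O)N1`, is not yet measured. It differs from compound 3 in one place: cyclopentyloxy in place of isopropylsulfanyl on a carbonyl carbon.

Among the compounds with values here, two measured steps touch the same carbonyl carbon. The step of no change at the digits printed from compound 1 to compound 3 (within the scatter) shows that exchanging cyclopropyl for isopropylsulfanyl left the number where it was, while a number 34 percentage points lower from compound 2 to compound 3 (beyond the scatter) shows that only the diethylamino group gave a high number. Within the data shown here, no ester has been measured, so the new cyclopentyloxy group has no direct precedent. Given that two of three variations sit at the floor, compound 4 is expected to stay low, with a step of a number 4 percentage points higher from compound 3 to compound 4 (within the scatter). The estimate for compound 4 is 5%, within 0% to 25%.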

Compound 4, a percentage reported as inhibition, at one concentration (the size of the read-out at that concentration, not a potency): 5%
For compound 4 middle estimate and measured number coincide at the digits printed; low and high end bracket the measured number.
By their numbers in this assay, from the lowest: compounds 1, 3 and 4 (each within the scatter of the next); then compound 2.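

In this assay, within the data shown here, cyclopentyloxy, the first ester group at this carbonyl carbon, falls in with the two low compounds: the steps are a number 4 percentage points higher from compound 3 to compound 4 (within the scatter) and a number 4 percentage points higher from compound 1 to compound 4 (within the scatter). The gap to the diethylamino group remains clear, with a number 30 percentage points lower from compound 2 to compound 4 (beyond the scatter), so among these four compounds diethylamino alone stands apart, and a ring joined through oxygen gives a number within the scatter of those for cyclopropyl and isopropylsulfanyl. The data offer no explanation for this split between diethylamino and the other three groups.

Still open, as far as these compounds go, is whether the higher number belongs to diethylamino in particular or extends to other amines at this carbonyl carbon, a question that a dimethylamino or pyrrolidinyl group would address. Each number in this assay also comes from a single concentration, which leaves the potency of these compounds open.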